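Ester to Carbamoyl: Estimating Lipophilicity of Compound 4

A few compounds are considered here, and "the series" means these few. Any claim that something is new, unique, unknown or untested is made for them only; others in the source may bear on it.

Compound 1: `CCOC(=O)c1ccc(/N=N/N(C)C(=O)[C@H](C)NC(C)=O)cc1` gives 2.52.
Compound 2: `CCCC(=O)N[C@@H](C)C(=O)N(C)/N=N/c1ccc(C#N)cc1` gives 2.28.
Compound 3: `C[C@H](NC(=O)c1ccccc1)C(=O)N(C)/N=N/c1ccc(C#N)cc1` gives 3.04.

These numbers come from a physicochemical assay for lipophilicity, read by HPLC, in phosphate buffer, measured as octanol-water partition, at pH 7.4; on this read-out higher numbers stand for higher lipophilicity and lower numbers for lower lipophilicity. Among the three, compound 1 stands second highest: compound 2 lies within the scatter of it, while compound 3 lies beyond the scatter above it. Going by the values given here, the only measured step in this assay, a number 0.76 log units higher from compound 2 to compound 3 (beyond the scatter), concerns a different place and does not bear on the change now considered. Compound 4, `CC(=O)N[C@@H](C)C(=O)N(C)/N=N/c1ccc(C(N)=O)cc1`, differs from compound 1 by amino in place of ethoxy on a carbonyl carbon. Among the compounds with values here, with no measured step covering this change, the expectation rests on the structures alone; the step of a number 1.42 log units lower from compound 1 to compound 4 (beyond the scatter) is expected to be downward and beyond the scatter. Compound 4 is estimated at 1.1, between 0.6 and 1.6.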

Compound 4, partition coefficient: 0.69
Estimate against measurement, compound 4: 0.41 log units above, and the stated range covers the measured number.
By their numbers in this assay, from the lowest: compound 4; then compounds 2 and 1 (each within the scatter of the next); then compound 3.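

In this assay, amino in place of ethoxy on a carbonyl carbon gives a number 1.83 log units lower from compound 1 to compound 4 (beyond the scatter), the first step measured at this position. Going by these compounds alone, the earlier compounds showed a change only at a different place, so this is the first sign that the group on this carbonyl carbon can shift the number by a large amount. Nothing available here explains the size of this step.

Where a methylamino group or a carboxylic acid would fall at this position remains open. So does whether a chain longer than ethoxy would give a higher number.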